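A Second Chloro Group and the Cytotoxicity Read-out

This account rests on a few compounds, and the source may have more. Where it says the series, first, only, none or still open, it means among the compounds named here.

Measured compounds:
Compound 1 `Cc1ccc2nc(Cl)c(/C=C3\C(=O)N(c4c(Cl)cccc4Cl)c4ccccc43)cc2c1`: "not determined" (no result reported)
Compound 2 `O=C1/C(=C\c2ccccc2Cl)c2ccccc2N1c1c(Cl)cccc1Cl`: > 100 ug/mL
Compound 3 `Cc1ccc2nc(Cl)c(/C=C3\C(=O)N(c4c(Cl)cccc4Cl)c4ccccc43)cc2c1C`: 98 ug/mL

All three share one core and were tested in a functional assay on L132 cells (Homo sapiens) for cytotoxicity, read by MTT assay, with a stated time of 72 h; on this read-out lower numbers stand for an effect already at smaller amounts and higher numbers for an effect only at larger amounts of compound. For compound 1 no result exists in this assay, only the entry "not determined" (no result reported). Compound 3 gives a number in this assay, 98 ug/mL. For compound 2 this assay reports only a limit, > 100 ug/mL, so compound 2 sits at the limit of > 100 ug/mL in this assay, at which 1 of the 3 values shown sits, the place where no single number is given.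

Compound 4 `O=C1/C(=C\c2c(Cl)cccc2Cl)c2ccccc2N1c1c(Cl)cccc1Cl` differs from compound 2 in one place:

chloro in place of hydrogen on an aromatic carbon

Going by the values given here, no pair of measured compounds differs in a single place, so no measured step shows how such a change moves this read-out. Compound 2 already lies at the limit of this assay, and one added chloro group gives no ground to expect a shift beyond the usual scatter. Compound 4 is therefore expected to show about the same result, a step of a number no higher from compound 2 to compound 4 (the limit leaves the size open), with the estimate for compound 4 at 100 ug/mL (range 50 ug/mL to 200 ug/mL), most likely again reported only as a limit.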

Compound 4, concentration for half-maximal effect: > 100 ug/mL
Compound 4: no number, only a limit (the forecaster's own chance of this, stated with the estimate: 70%); the middle value lies on the limit itself.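

In this assay, going by these compounds alone, compound 2 and compound 4 are each reported only as a limit and not as a number, so no step between them can be read: the limit of > 100 ug/mL in this assay, at which 2 of the 4 values shown sit.

The compounds shown leave open whether going from 2-chlorophenyl to 2,6-dichlorophenyl changes this cytotoxicity result at all, and by how much.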